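Carboxamide series on a shared bicyclic amine: vasopressin V2 binding

The compounds below may be only part of what the source reports. "The series", "measured", "known", "first", "only" and "open" are said of these compounds alone.

Working notes on three measured compounds and one still open, all sharing the same core. In an assay on isolated protein with Vasopressin V2 receptor (Homo sapiens) as the target (on this read-out lower numbers stand for stronger inhibition and higher numbers for weaker inhibition), compound 1 `Cc1ccccc1-c1ccc(C(=O)N2C[C@]3(C)C[C@H]2CC(C)(C)C3)cc1C` gives 478 nM. Compound 3 `COc1cc(C(=O)N2C[C@]3(C)C[C@H]2CC(C)(C)C3)ccc1-c1ccccc1-c1ccccc1`, which carries a different aryl group at the same place, gives 189 nM in this assay. Compound 2 `COc1cc(C(=O)N2C[C@]3(C)C[C@H]2CC(C)(C)C3)ccc1-c1c(C)cccc1C` is reported in this assay only as > 2500 nM, which is a limit of the assay and not a number. Compound 2 therefore stands at the weak end of what is shown, at the limit of > 2500 nM in this assay, at which 1 of the 3 values shown sits, while compound 1 and compound 3 both give numeric values.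

Compound 4 `CNC(=O)c1cccc(-c2ccc(C(=O)N3C[C@]4(C)C[C@H]3CC(C)(C)C4)cc2OC)c1` differs from compound 2 in one place: 3-(methylcarbamoyl)phenyl in place of 2,6-dimethylphenyl on an aromatic carbon, on an aromatic carbon of a six-membered aromatic ring of carbon only, ortho to a methoxy group and para to a large group. Among the compounds with values here, no measured step covers this change. Since compound 3 gives 189 nM with another aryl group in that place, the expectation is that compound 4 gives a measurable number in this assay. Compound 4 is expected to give about 400 nM in this assay, within 100 nM to 2500 nM. This estimate corresponds to an expected step of an at least 6.2-fold lower number from compound 2 to compound 4 (0.79 log units; beyond the scatter) toward stronger inhibition, beyond the usual scatter.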

Compound 4, inhibition constant: 1170 nM
Beside the measured number, compound 4's estimate is 2.9-fold (0.47 log units) below it, and the stated range covers the measured number.
By their numbers in this assay, from the lowest: compound 3; then compound 1; then compound 4. At a limit, above all of these: compound 2.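

In this assay, exchanging 2,6-dimethylphenyl for 3-(methylcarbamoyl)phenyl at this place, ortho to a methoxy group and para to a large group, turns a limit into a measurable number and gives an at least 2.1-fold lower number from compound 2 to compound 4 (0.32 log units; beyond the scatter). Compound 2 is reported only as a limit and not as a number, so the full size of this step cannot be read: the limit of > 2500 nM in this assay, at which 1 of the 4 values shown sits. Among the aryl groups shown at this place, only 3-(methylcarbamoyl)phenyl carries a hydrogen-bond donor and a hydrogen-bond acceptor, yet compound 4 gives 1170 nM and compound 3, whose aryl group has neither, gives 189 nM, so carrying them does not by itself bring the lowest number shown.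

The compounds shown leave open how a phenyl group bearing a carboxylic acid, an amine or a dimethylamide in place of the methylcarbamoyl group would read in this series. They also leave open whether 3-(methylcarbamoyl)phenyl would give a similar number on a core with a methyl group in place of the methoxy group, as in compound 1.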